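The source may report more compounds than this note shows. Statements on the series, on what has been measured and on what is new or still open speak of the compounds shown alone.

Compound 3 `Cc1cccc(NC(=O)CN2CCC(c3cccc(O)c3)CC2)c1` gives 8 nM in a functional assay on HEK293 cells for agonist activity at D(4) dopamine receptor (Homo sapiens), read by FLIPR (a lower number here means that less compound is needed, a higher number that more compound is needed for the effect), level with compound 1 `Cc1cccc(NC(=O)CN2CCC(c3ccccc3C#N)CC2)c1`, whose value is 8 nM; together they are the lowest of the three numbers, since compound 2 `Cc1cccc(NC(=O)CN2CCC(c3ccc(O)cc3)CC2)c1` gives 70 nM and the step of an 8.8-fold lower number from compound 2 to compound 3 (0.94 log units; beyond the scatter) lies beyond the scatter. Compound 4 `Cc1cccc(NC(=O)CN2CCC(c3cccc(C#N)n3)CC2)c1` differs from compound 3 by 6-cyanopyridin-2-yl in place of 3-hydroxyphenyl on a saturated ring carbon. Among the measured compounds shown here, two measured steps bear on this: no change at the digits printed from compound 1 to compound 3 (within the scatter) shows that a 2-cyanophenyl and a 3-hydroxyphenyl on this saturated ring carbon give the same number, while an 8.8-fold higher number from compound 1 to compound 2 (0.94 log units; beyond the scatter) shows that moving to a 4-hydroxyphenyl costs a modest amount. For the measured compounds named here, no measured step covers a pyridine ring on this carbon. The account therefore expects a step of about a 1.9-fold higher number from compound 3 to compound 4 (0.27 log units; within the scatter), and estimates compound 4 at 15 nM, within 4 nM to 60 nM.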

Compound 4, half-maximal effective concentration: 36 nM
Compound 4: middle estimate off by 2.4-fold (0.38 log units), on the low side, within the range that was stated.
By their numbers in this assay, from the lowest: compounds 1 and 3 (each within the scatter of the next); then compounds 4 and 2 (each within the scatter of the next).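

On this saturated ring carbon, a nitrile-bearing pyridine ring does not hold the level of the 2-cyanophenyl or 3-hydroxyphenyl groups in this assay (a 4.5-fold higher number from compound 1 to compound 4 (0.65 log units; beyond the scatter); a 4.5-fold higher number from compound 3 to compound 4 (0.65 log units; beyond the scatter)). Its step from the 4-hydroxyphenyl group stays within the scatter (a 1.9-fold lower number from compound 2 to compound 4 (0.29 log units; within the scatter)), so in this set a ring with no hydroxyl group reads level with that phenol. No measured evidence at hand accounts for these steps. The compounds shown leave open whether the ring nitrogen or the place of the nitrile carries the change, and how a 3-aminophenyl or 3-carboxyphenyl group on this carbon would read.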